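Permeability notes: aryl replacement on the shared core

A few compounds are considered here, and "the series" means these few. Any claim that something is new, unique, unknown or untested is made for them only; others in the source may bear on it.

Measured so far:
compound 1 `COc1ccc(-c2ccc3c(NCCCNCc4ccco4)ccnc3c2)cc1` — 237 10^-6 cm/s
compound 2 `COc1ccc(-c2ccc3c(NCCCNCc4cc(F)ccc4OC)ccnc3c2)cc1` — 237 10^-6 cm/s

In an ADME assay for permeability, using PAMPA, with a stated time of 30 min, at pH 7.4 (a lower number here means that the compound crosses the layer more slowly, a higher number that the compound crosses the layer faster), compound 1 gives 237 10^-6 cm/s and compound 2 gives 237 10^-6 cm/s; the two stand level at the digits printed, within the scatter. Among the measured compounds shown here, the one measured step, no change at the digits printed from compound 1 to compound 2 (within the scatter), concerns the saturated chain carbon bound to an amine nitrogen and shows no change beyond the scatter. Compound 3 `N#Cc1ccc(Cc2ccc3c(NCCCNCc4ccco4)ccnc3c2)cc1` is not yet measured. It differs from compound 1 by 4-cyanobenzyl in place of 4-methoxyphenyl on an aromatic carbon. For the measured compounds named here, no measured step touches this position of the shared core, so the expectation rests only on the flat behaviour seen so far. Given that neither value shows movement, the step of a 1.2-fold lower number from compound 1 to compound 3 (0.07 log units; within the scatter) is expected to be small, if anything slightly downward, and within the scatter. Compound 3 is therefore estimated at 200 10^-6 cm/s, with a range from 110 10^-6 cm/s to 320 10^-6 cm/s.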

Compound 3, apparent permeability: 23 10^-6 cm/s
Compound 3: the middle estimate sits 8.7-fold (0.94 log units) above what was measured, outside the stated range (below it).
By their numbers in this assay, from the lowest: compound 3; then compounds 1 and 2 (each within the scatter of the next).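

In this assay the aromatic carbon of the shared core responds strongly: 4-cyanobenzyl in place of 4-methoxyphenyl gives a 10-fold lower number from compound 1 to compound 3 (1.01 log units; beyond the scatter), whereas the change on the saturated chain carbon bound to an amine nitrogen gave no change at the digits printed from compound 1 to compound 2 (within the scatter). So the flat picture from the chain change does not carry over to this position. The groups that leave and enter each hold one six-membered aromatic ring of carbon only and carry no net charge, and nothing measured here explains the lower number.

The compounds shown leave open whether the step follows the nitrile or the methylene link, as both change together. A 4-cyanophenyl or a 4-methoxybenzyl group on this aromatic carbon would separate the two.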